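Chloro to nitro: an expectation for compound 4

The compounds below may be only part of what the source reports. "The series", "measured", "known", "first", "only" and "open" are said of these compounds alone.

Compound 1 `O=C(Nc1ccccc1)c1cn(-c2ccccc2)nc1-c1ccc(Cl)cc1`: 2340 nM
Compound 2 `O=C(Nc1ccc(Cl)cc1)c1cn(-c2ccccc2)nc1-c1ccc(Cl)cc1`: 3750 nM
Compound 3 `CCOc1ccc(NC(=O)c2cn(-c3ccccc3)nc2-c2ccc(Cl)cc2)cc1`: 560 nM

In a functional assay on MCF7 cells (Homo sapiens) for cytotoxicity, read by MTT assay, with a stated time of 48 h (a lower number here means a stronger inhibitor, a higher number a weaker inhibitor), compound 1 gives 2340 nM, compound 2 gives 3750 nM and compound 3 gives 560 nM. Compound 3 has the lowest of the three numbers: the steps of a 4.2-fold lower number from compound 1 to compound 3 (0.62 log units; beyond the scatter) and a 6.7-fold lower number from compound 2 to compound 3 (0.83 log units; beyond the scatter) both lie beyond the scatter, whereas a 1.6-fold higher number from compound 1 to compound 2 (0.20 log units; within the scatter) lies within it. Compound 4 `CCOc1ccc(NC(=O)c2cn(-c3ccccc3)nc2-c2ccc([N+](=O)[O-])cc2)cc1` differs from compound 3 by nitro in place of chloro on an aromatic carbon. Going by the values given here, no measured step touches this position; the three measured changes all sit on another aromatic carbon of a different ring, so they bear on the new step only as a rough guide to how much a single small substituent swap has moved the numbers here, from within the scatter to modest. Among the compounds with values here, with no direct precedent, the step of a 1.3-fold higher number from compound 3 to compound 4 (0.10 log units; within the scatter) is expected to stay within the scatter. Compound 4 is therefore estimated at 700 nM, with a range from 200 nM to 2500 nM.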

Compound 4, half-maximal inhibitory concentration: 460 nM
Estimate against measurement, compound 4: 1.5-fold (0.18 log units) above, within the range that was stated.
By their numbers in this assay, from the lowest: compounds 4 and 3 (each within the scatter of the next); then compounds 1 and 2 (each within the scatter of the next).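

In this assay, going by these compounds alone, the first step at this position, on the aromatic carbon para to a large group, is a 1.2-fold lower number from compound 3 to compound 4 (0.09 log units; within the scatter), which lies within the scatter. Nitro brings three heavy atoms and two hydrogen-bond acceptors where chloro had one heavy atom and none, yet the two compounds cannot be told apart here, whereas the earlier steps beyond the scatter all sat on a different ring. Nothing available accounts for this result.

The compounds shown leave open whether an amine or a carboxylic acid on this carbon would also stay within the scatter. They also leave open whether nitro in place of chloro would read the same with hydrogen instead of ethoxy on the other ring.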